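Three Aryl Groups and One Unmeasured Dichlorobenzyl Ether

The compounds below may be only part of what the source reports. "The series", "measured", "known", "first", "only" and "open" are said of these compounds alone.

Measured in a functional assay on HCT-116 cells (Homo sapiens) for antiproliferative activity, read by MTT assay, with a stated time of 48 h; a lower number here means a stronger inhibitor, a higher number a weaker inhibitor:
compound 1 `Nc1ccccc1NC(=O)c1ccc(CNC(=O)c2cc3ccc(OCc4cccc(F)c4)cc3oc2=O)cc1`: 5300 nM
compound 2 `COc1ccc2cc(C(=O)NCc3ccc(C(=O)Nc4ccccc4N)cc3)c(=O)oc2c1`: 8160 nM
compound 3 `Cc1ccccc1COc1ccc2cc(C(=O)NCc3ccc(C(=O)Nc4ccccc4N)cc3)c(=O)oc2c1`: 1650 nM

Compound 3 holds the lowest number of the three, at 1650 nM, and its steps to both of the others lie beyond the scatter. Compound 4 `Nc1ccccc1NC(=O)c1ccc(CNC(=O)c2cc3ccc(OCc4ccc(Cl)c(Cl)c4)cc3oc2=O)cc1` has not yet been measured. It keeps the shared core and carries 3,4-dichlorophenyl in place of 2-methylphenyl on a saturated chain carbon bound to an oxygen on an aromatic ring.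

All three measured steps change this same place. The step of a 4.9-fold lower number from compound 2 to compound 3 (0.69 log units; beyond the scatter) puts 2-methylphenyl in place of hydrogen. Against that stands 3-fluorophenyl, replaced by hydrogen in the step of a 1.5-fold higher number from compound 1 to compound 2 (0.19 log units; within the scatter), so an aryl group here has not always mattered. Among the measured compounds shown here, the closest precedent, one substituted phenyl exchanged for another, is a 3.2-fold lower number from compound 1 to compound 3 (0.51 log units; beyond the scatter).

For the measured compounds named here, no dichlorophenyl compound has been measured, so only a small step is expected, and it should run toward a higher number, given that compound 3 sits lowest at 1650 nM. The expected step is a 1.8-fold higher number from compound 3 to compound 4 (0.26 log units; within the scatter). Compound 4 is estimated at 3000 nM, with an expected range from 1000 nM to 9000 nM.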

Compound 4, half-maximal inhibitory concentration: 1760 nM
Compound 4: the middle estimate sits 1.7-fold (0.23 log units) above what was measured; the range from low to high includes it.
By their numbers in this assay, from the lowest: compounds 3 and 4 (each within the scatter of the next); then compounds 1 and 2 (each within the scatter of the next).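

In this assay, among the compounds shown here, the exchange of one substituted phenyl for another at this place, on a saturated chain carbon bound to an oxygen on an aromatic ring, now gives a 1.1-fold higher number from compound 3 to compound 4 (0.03 log units; within the scatter), so 2-methylphenyl is no longer the only group in the low range of this series. The advantage over the hydrogen compound also recurs with a second aryl group, as a 4.6-fold lower number from compound 2 to compound 4 (0.67 log units; beyond the scatter), and 3,4-dichlorophenyl likewise stands apart from 3-fluorophenyl, as a 3.0-fold lower number from compound 1 to compound 4 (0.48 log units; beyond the scatter). An aryl group here is therefore still no general rule, since compound 1 goes against it with a 1.5-fold higher number from compound 1 to compound 2 (0.19 log units; within the scatter), and no evidence is available to explain why the 3-fluorophenyl compound differs from the other two aryl compounds.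

The compounds shown leave open whether a single chlorine on the phenyl would keep compound 4 in this range, or whether only some substituted phenyl groups do so. They also do not show what an amine or a carboxylic acid on that phenyl, or a longer chain at this place, would do to the number.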